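Butylamide Next: Expected Step from Unsubstituted Amide

The compounds below may be only part of what the source reports. "The series", "measured", "known", "first", "only" and "open" are said of these compounds alone.

Of the compounds shown here, two sharing one core have so far been measured in a functional assay on HTB-54 cells (Homo sapiens) for cytotoxicity, read by MTT assay, with a stated time of 72 h; on this read-out higher numbers stand for weaker inhibition of growth and lower numbers for stronger inhibition of growth. Compound 1 `NC(=O)c1ccc2c(c1)S(=O)(=O)C=C2` carries an unsubstituted amide and in this assay gives 220 nM, the highest of the two numbers. Compound 2 `COc1ccc(NC(=O)c2ccc3c(c2)S(=O)(=O)C=C3)cc1`, whose amide nitrogen carries a substituent, gives 2 nM in this assay, a far lower number that lies beyond the usual scatter. For the measured compounds named here, no step between measured compounds differing in a single place is available, so the effect of substituting the amide nitrogen alone has not been isolated.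

Compound 3 `CCCCNC(=O)c1ccc2c(c1)S(=O)(=O)C=C2` is the next compound to be measured. It differs from compound 1 by butyl in place of hydrogen on an amide-type nitrogen. The values of compound 1 and compound 2 show that a substituted amide nitrogen can go with a much lower number, although that example carries a ring rather than a chain. The account therefore expects compound 3 to sit below compound 1, with the step of a 4.4-fold lower number from compound 1 to compound 3 (0.64 log units; beyond the scatter) expected to be moderate and beyond the scatter. Compound 3 is estimated at 50 nM in this assay, within a range from 10 nM to 250 nM.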

Compound 3, concentration for 50% growth inhibition: 90 nM
The estimate for compound 3 lay 1.8-fold (0.26 log units) below the measured number; the range from low to high includes it.
By their numbers in this assay, from the lowest: compound 2; then compound 3; then compound 1.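

The step from the unsubstituted amide can now be read on its own: in this assay butyl in place of the amide hydrogen gives a 2.4-fold lower number from compound 1 to compound 3 (0.39 log units; beyond the scatter) and so shows that a plain open chain on this nitrogen goes with a lower number, without any ring. The step is modest, and compound 3 at 90 nM stays well above compound 2 at 2 nM on these printed values, so the butyl chain reaches only part of the way from compound 1 towards compound 2. Nothing available bears on what lies behind the lower number of compound 3.

From the compounds shown here alone, whether a shorter chain such as methyl, a longer chain such as octyl, or a butyl chain ending in an amine or a carboxylic acid would sit above or below compound 3 remains open. Also open, going by these compounds, is whether the low number of compound 2 goes with its ring or with its methoxy group, a question that a plain phenyl on the same nitrogen would address.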